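The source may report more compounds than this note shows. Statements on the series, on what has been measured and on what is new or still open speak of the compounds shown alone.

Working notes on the series.

Three compounds carry numbers in an ADME assay on microsomes from liver (Homo sapiens) for metabolic stability, tested at 2.5 uM; a higher number here means faster removal of the compound, a lower number slower removal. Compound 1, `O=S(=O)(c1ccc(F)c(F)c1)c1cnc2c(F)cccc2c1-c1ccc(Cl)cc1`, gives 0.28 mL/min. Compound 2, `O=S(=O)(c1cc(F)cc(F)c1)c1cnc2c(F)cccc2c1-c1ccccc1F`, gives 0.09 mL/min. Compound 3, `COc1ccc(S(=O)(=O)c2cnc3c(F)cccc3c2-c2cccc(F)c2)cc1`, gives 3.03 mL/min, the highest of the three; its gap to compound 1 and its gap to compound 2 both lie beyond the usual scatter of this assay. Compound 3 is also the only one of the three whose sulfone bears a methoxyphenyl group, and the other two differ from it in more than one place, so no single-change comparison is available among the measured compounds.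

Compound 4, `COc1ccc(S(=O)(=O)c2cnc3c(F)cccc3c2-c2ccc(Cl)cc2)cc1`, has not yet been measured. It differs from compound 3 in one place: 4-chlorophenyl in place of 3-fluorophenyl on an aromatic carbon. The 4-chlorophenyl it gains is also the group found in compound 1, whereas compound 2 carries a 2-fluorophenyl in that position; the two values of compound 1 and compound 2 are within the scatter of each other, so what the ring on this carbon contributes cannot be read from them. The methoxyphenyl sulfone that sets compound 3 apart is kept in compound 4.

The step from compound 3 to compound 4 is therefore expected to be small, a 1.4-fold lower number from compound 3 to compound 4 (0.14 log units; within the scatter), with no clear direction and probably within the scatter. Compound 4 is expected to give about 2.2 mL/min in this assay, with a likely range from 0.8 mL/min to 5.5 mL/min.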

Compound 4, intrinsic clearance in a liver preparation (reported as CLH), per the amount of preparation that the assay uses: 1.05 mL/min
Compound 4: middle estimate off by 2.1-fold (0.32 log units), on the high side, within the range that was stated.
By their numbers in this assay, from the lowest: compound 2; then compound 1; then compound 4; then compound 3.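

In this assay, for the compounds shown here, the ring on this aromatic carbon, opposite the ring nitrogen, now shows a readable effect: 4-chlorophenyl in place of 3-fluorophenyl gives a 2.9-fold lower number from compound 3 to compound 4 (0.46 log units; beyond the scatter) and lies beyond the scatter, something the earlier compounds could not show, as none of them differed from another in one place. The sulfonyl sulfur also gains its first single-change comparison: with 4-chlorophenyl held constant, 4-methoxyphenyl in place of 3,4-difluorophenyl gives a 3.8-fold higher number from compound 1 to compound 4 (0.57 log units; beyond the scatter) and also lies beyond the scatter, so a change in either place alone moves the number in this series. No measurement at hand accounts for either step.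

As far as these compounds go, it remains open whether the first step follows from the change of halogen, from its place on the phenyl ring, or from both, and whether it would carry over to a sulfone bearing 3,4-difluorophenyl. The compounds shown also leave open how the number would respond to an amine or a carboxylic acid on either phenyl ring, or to a longer alkyl chain in place of the aryl group on the sulfonyl sulfur.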